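A few compounds are considered here, and "the series" means these few. Any claim that something is new, unique, unknown or untested is made for them only; others in the source may bear on it.

Compound 1 `COc1ccc(C(=O)/C=C/c2cc(OC)c(OC)c(OC)c2)c2c1C=CC(C)(C)O2`: 9700 nM
Compound 2 `COc1ccc(C(=O)/C=C/c2ccc(N3CCCC3)cc2)c2c1C=CC(C)(C)O2`: 7370 nM
Compound 3 `COc1ccc(C(=O)/C=C/c2cccc(C(F)(F)F)c2)c2c1C=CC(C)(C)O2`: 9330 nM

Of the compounds shown here, three built on one shared core have so far been tested in a functional assay on SK-OV-3 cells (Homo sapiens) for antiproliferative activity, read by MTT assay, with a stated time of 24 h; on this read-out higher numbers stand for weaker inhibition and lower numbers for stronger inhibition. Compound 1 gives 9700 nM, compound 2 gives 7370 nM and compound 3 gives 9330 nM. Compound 2 stands at the lowest of the three numbers, yet its gaps to compound 3 and to compound 1 both lie within the usual scatter of repeated measurements, so the three compounds cannot be told apart on these data.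

The next compound, compound 4 `COc1ccc(C(=O)/C=C/c2ccc(Cl)cc2)c2c1C=CC(C)(C)O2`, has not yet been measured. It differs from compound 2 in one place: chloro in place of pyrrolidin-1-yl on an aromatic carbon. For the measured compounds named here, no pair of measured compounds differing in a single place is available, so no measured step can guide the expectation. The three measured compounds, carrying quite different groups, all fall close together, so no step beyond the scatter is expected in either direction. Compound 4 is estimated at 9000 nM, with a range from 4000 nM to 20000 nM. This corresponds to an expected step of a 1.2-fold higher number from compound 2 to compound 4 (0.09 log units; within the scatter).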

Compound 4, half-maximal inhibitory concentration: > 10000 nM
Compound 4 was reported as a limit (the forecaster's own chance of this, stated with the estimate: 5%); at least 1.1-fold (0.04 log units) between middle value and limit.
By their numbers in this assay, from the lowest: compounds 2, 3 and 1 (each within the scatter of the next). At a limit, above all of these: compound 4.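

In this assay compound 4 is reported only as a limit, > 10000 nM, and not as a number. Chloro in place of pyrrolidin-1-yl on an aromatic carbon, para to a large group, gives the first single-place step in this set, an at least 1.3-fold higher number from compound 2 to compound 4 (0.13 log units; that floor lies within the scatter), so this position now has one measured change, though its floor does not clear the scatter. Only that floor can be read, not the full size of the step, because compound 4 sits at a limit: the limit of > 10000 nM in this assay, at which 1 of the 4 values shown sits.

On these data alone, it stays open whether this change truly separates compound 4 from compound 2 or whether the two differ by no more than the scatter. The compounds shown also leave open how another amine, such as dimethylamino or morpholin-4-yl, would read at this position.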